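Swapping cyclopentyl for benzyl on a sulfur

The source may report more compounds than this note shows. Statements on the series, on what has been measured and on what is new or still open speak of the compounds shown alone.

In an ADME assay on MOLT-3 cells (Homo sapiens) for cytotoxicity, with a stated time of 7 days (a lower number here means that less compound is tolerated, a higher number that more compound is tolerated), compound 2 (`Nc1nc(SC2CCCC2)c2ncn(/C=C3/CC3(CO)CO)c2n1`) gives > 20000 nM as a limit of the assay, not as a number. Compound 1 (`CNc1nc(N)nc2c1ncn2/C=C1/CC1(CO)CO`) gives > 20000 nM as a limit of the assay too. Among the compounds with values here, the only measured step is a step that the two limits leave unreadable from compound 1 to compound 2 and it offers no size to carry forward. Everything measured so far amounts to the limit of > 20000 nM in this assay, at which 2 of the 2 values shown sit, with no actual number among the results.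

Compound 3 (`Nc1nc(SCc2ccccc2)c2ncn(/C=C3/CC3(CO)CO)c2n1`) keeps the shared core and changes one group: benzyl in place of cyclopentyl on a sulfur so that cyclopentylsulfanyl becomes benzylsulfanyl. Within the data shown here, with compound 2 resting on > 20000 nM as a limit, no measured step points in either direction. No step beyond the scatter is therefore expected in this assay and another limit is the likeliest report. The expected change is a number no higher from compound 2 to compound 3 (the limit leaves the size open) in this estimate. Compound 3 is expected near 20000 nM with a range from 9000 nM to 40000 nM as its estimated span.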

Compound 3, half-maximal cytotoxic concentration: > 20000 nM
Compound 3 was reported as a limit; the forecaster's own chance of this, stated with the estimate: 75%; the middle value lies on the limit itself.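

Within the data shown here, compound 3, like compound 1 and compound 2, is reported in this assay only as a limit and not as a number, so no step between these compounds can be read. The compounds shown leave open whether methylamino, cyclopentylsulfanyl and benzylsulfanyl differ at all in this read-out, with every result resting at one value: the limit of > 20000 nM in this assay, at which 3 of the 3 values shown sit.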